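This account rests on a few compounds, and the source may have more. Where it says the series, first, only, none or still open, it means among the compounds named here.

Measured compounds in an assay on cells (Oocyte) for inhibition of sodium- and chloride-dependent neutral and basic amino acid transporter B(0+) (Homo sapiens), read by LC-MS, with a stated time of 10 min; a lower number here means a stronger inhibitor, a higher number a weaker inhibitor:
compound 1 `N[C@@H](CC(=O)OC[C@H]1O[C@@H](n2cc(F)c(=O)[nH]c2=O)C[C@@H]1O)C(=O)O`: 820000 nM
compound 2 `CC(C)[C@H](N)C(=O)OC[C@H]1O[C@@H](n2cc(F)c(=O)[nH]c2=O)C[C@@H]1O`: 980000 nM
compound 3 `CC(C)[C@H](N)C(=O)OC[C@H]1O[C@@H](n2cc(F)c(=O)[nH]c2=O)C[C@@H]1OC(=O)[C@@H](N)C(C)C`: 2010000 nM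

Compound 2 stands second highest of the three numbers. Its nearest neighbour is compound 1, a 1.2-fold higher number from compound 1 to compound 2 (0.08 log units; within the scatter), a step within the scatter. Its furthest is compound 3, a 2.1-fold higher number from compound 2 to compound 3 (0.31 log units; beyond the scatter), a modest step beyond the scatter.

Compound 4 `N[C@@H](CCC(=O)OC[C@H]1O[C@@H](n2cc(F)c(=O)[nH]c2=O)C[C@@H]1O)C(=O)O` is not yet measured. It differs from compound 2 in one place: 3-amino-3-carboxypropyl in place of 1-amino-2-methylpropyl on a carbonyl carbon. Within the data shown here, the measured step that bears on this change is the one from compound 1 to compound 2, where a chain carrying an amino group and a carboxy group gave way to the 1-amino-2-methylpropyl group and the number moved only within the scatter (a 1.2-fold higher number from compound 1 to compound 2 (0.08 log units; within the scatter)). Compound 4 brings back a chain carrying an amino group and a carboxy group, here the 3-amino-3-carboxypropyl group. The step from compound 2 to compound 3 concerns the oxygen on a saturated carbon and does not bear directly. The expected step in this assay is therefore small, toward a somewhat lower number, most likely within the scatter. Compound 4 is estimated at 750000 nM (range 350000 nM to 1600000 nM), which means an expected step of a 1.3-fold lower number from compound 2 to compound 4 (0.12 log units; within the scatter).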

Compound 4, half-maximal inhibitory concentration: 1130000 nM
The estimate for compound 4 lay 1.5-fold (0.18 log units) below the measured number; measured number inside the range.
By their numbers in this assay, from the lowest: compounds 1, 2, 4 and 3 (each within the scatter of the next, the first and the last beyond it).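

In this assay, replacing the 1-amino-2-methylpropyl group with the 3-amino-3-carboxypropyl group on this carbonyl carbon gives a 1.2-fold higher number from compound 2 to compound 4 (0.06 log units; within the scatter), so adding the carboxy-bearing chain to the comparison with the branched group leaves the two unresolved. Going from the 2-amino-2-carboxyethyl chain to the longer 3-amino-3-carboxypropyl chain gives a 1.4-fold higher number from compound 1 to compound 4 (0.14 log units; within the scatter), so this first test of chain length at the position also stays within the scatter. Nothing at hand accounts for this flat response at the carbonyl carbon.

As far as these compounds go, it remains open whether a plain alkyl chain with no amine, or a chain ending in a carboxylic acid with no amine, would shift the number beyond the scatter at this position. A longer chain carrying both the amine and the carboxylic acid is also untested among the compounds shown.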